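The compounds below may be only part of what the source reports. "The series", "measured", "known", "first", "only" and "open" are said of these compounds alone.

The compounds measured so far:
compound 1, `OCc1ccc(CNc2cc(Br)cc3[nH]ncc23)cc1`, 56%
compound 2, `CC(=O)Nc1ccc(CNc2cc(Br)cc3[nH]ncc23)cc1`, "not active" (no number reported)

Both share one core and differ only in a single group. In an assay for inhibition of Tryptophan 2,3-dioxygenase (Homo sapiens), with a stated time of 1 h, tested at 10 uM (on this read-out lower numbers stand for less inhibition and higher numbers for more inhibition at the one concentration tested (going by the name of the read-out)), compound 1 gives 56%. In this assay compound 2 is reported as "not active" (no number reported), so no single number stands for it; it is the one of the two measured compounds for which no inhibition worth reporting was seen, while compound 1 shows measurable inhibition.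

Compound 3, `Nc1ccc(CNc2cc(Br)cc3[nH]ncc23)cc1`, has not been measured. It differs from compound 2 in one place: hydrogen in place of acetyl on a nitrogen on an aromatic ring. Within the data shown here, no step between measured compounds is recorded, so the size of this change cannot be read from any measured pair. What is known is that exchanging one group in this series moved the result from a moderate value to none. The step from compound 2 to compound 3 is expected to go upward in this assay by a modest amount, though it may also stay within the scatter. For compound 3 the expected value in this assay is 30%, with a range from 5% to 60%.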

Compound 3, a percentage reported as inhibition, at one concentration (the size of the read-out at that concentration, not a potency): 24%
For compound 3 the middle estimate is 6 percentage points above the measured one, and the stated range covers the measured number.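

In this assay compound 3 gives 24%, while compound 2 is reported as "not active" (no number reported), so replacing acetamido with amino on the aromatic ring gives a measurable value where the acetamido compound has none, although no numerical step can be read for this pair. Amino does not, however, reach the level seen with hydroxymethyl on the same aromatic carbon: a number 32 percentage points lower from compound 1 to compound 3 (beyond the scatter), so in this assay moving away from acetamido is not enough by itself to match compound 1. The data offer no independent measurement that explains this difference among the three groups.

As far as these compounds go, it remains open how a carboxylic acid, a methoxymethyl group or a longer chain such as hydroxyethyl would compare on that aromatic carbon, and so whether the result for hydroxymethyl is specific to that group or shared by others. Each value also comes from a single tested concentration, so the comparison shows the size of the inhibition at that concentration and leaves potency open.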